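Pyrimidinone series: single chlorophenyl replacing dimethoxyphenyl

The compounds below may be only part of what the source reports. "The series", "measured", "known", "first", "only" and "open" are said of these compounds alone.

Three analogues share a core and differ only in the aryl group on the pyrimidinone. In a functional assay on U-87MG ATCC cells for antiproliferative activity against U-87 MG (Homo sapiens), read by MTT assay, with a stated time of 48 h, tested at 50 uM (on this read-out lower numbers stand for a stronger effect and higher numbers for a weaker effect at the one concentration tested), compound 1 `Cc1nc(-c2ccc(Cl)cc2)sc1C(=O)CSc1nc(-c2ccc(Cl)c(Cl)c2)c(C#N)c(=O)[nH]1` gives 93.9%, compound 2 `Cc1nc(-c2ccc(Cl)cc2)sc1C(=O)CSc1nc(-c2cccc(Cl)c2)c(C#N)c(=O)[nH]1` gives 52.6%, and compound 3 `COc1ccc(-c2nc(SCC(=O)c3sc(-c4ccc(Cl)cc4)nc3C)[nH]c(=O)c2C#N)cc1OC` gives 59.8%. Compound 3 is the second highest of the three numbers; its nearest neighbour is compound 2, with a number 7.2 percentage points higher from compound 2 to compound 3 (within the scatter), while the furthest is compound 1, with a number 34.1 percentage points lower from compound 1 to compound 3 (beyond the scatter).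

Compound 4 `Cc1nc(-c2ccc(Cl)cc2)sc1C(=O)CSc1nc(-c2ccc(Cl)cc2)c(C#N)c(=O)[nH]1` differs from compound 3 by 4-chlorophenyl in place of 3,4-dimethoxyphenyl on an aromatic carbon. Going by the values given here, two measured steps bear on this. Removing one chloro gave a number 41.3 percentage points lower from compound 1 to compound 2 (beyond the scatter), and swapping a single chlorophenyl for the dimethoxyphenyl gave a number 7.2 percentage points higher from compound 2 to compound 3 (within the scatter). Since compound 4 carries a single chloro, as compound 2 does, the expected outcome is closer to the second of these steps than to the first: no change beyond the scatter is expected, so a number 2.2 percentage points higher from compound 3 to compound 4 (within the scatter) is the estimated step. Compound 4 is accordingly expected to give about 62% in this assay, estimated to lie between 42% and 88%.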

Compound 4, a percentage reported as activity, at one concentration (the size of the read-out at that concentration, not a potency): 60%
Compound 4: middle estimate off by 2 percentage points, on the high side; low and high end bracket the measured number.
By their numbers in this assay, from the lowest: compounds 2, 3 and 4 (each within the scatter of the next); then compound 1.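

In this assay the place of the single chloro on the phenyl cannot be told apart, with a number 7.4 percentage points higher from compound 2 to compound 4 (within the scatter), and 4-chlorophenyl cannot be told apart from 3,4-dimethoxyphenyl, with a number 0.2 percentage points higher from compound 3 to compound 4 (within the scatter). Taking away the other chloro of the 3,4-dichlorophenyl group gives a number 33.9 percentage points lower from compound 1 to compound 4 (beyond the scatter), so the loss of either chloro lowers the number beyond the scatter, and of the four aryl groups only the 3,4-dichlorophenyl of compound 1 stands apart. Nothing available explains this difference.

Open, on these data alone, is whether an unsubstituted phenyl, or a phenyl carrying an amine or a carboxylic acid, would group with compounds 2, 3 and 4 or with compound 1. The single tested concentration also leaves the potency of all four compounds undefined.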